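The source may hold more compounds than are shown below. What is called first, only, known or untested is meant among the compounds shown, and "the series" means these compounds.

Measured so far in this study:
Compound 1, `CN(C)c1ccc(-c2cccc(N)c2)cc1`: 70%
Compound 2, `CN(C)C(=O)Nc1cccc(-c2ccc(N(C)C)cc2)c1`: 98%
Compound 3, `CC(C)COC(=O)Nc1cccc(-c2ccc(N(C)C)cc2)c1`: 90%

These three compounds share one core and differ only in what sits on the nitrogen of the aromatic amine; all were tested in an assay on COS-7 cells for inhibition of patatin-like phospholipase domain-containing protein 2 (Mus musculus), tested at 200 uM; a lower number here means less inhibition, a higher number more inhibition at the concentration tested (going by the name of the read-out). Compound 3 stands second highest of the three: its value lies within the usual scatter of that of compound 2, while the step of a number 20 percentage points higher from compound 1 to compound 3 (beyond the scatter) lies beyond it. Compound 4, `CN(C)c1ccc(-c2cccc(NC(=O)N3CCOCC3)c2)cc1`, has not yet been measured. It differs from compound 3 in a single place: morpholin-4-yl in place of isobutoxy on a carbonyl carbon. The step that bears most directly on this change is a number 8 percentage points lower from compound 2 to compound 3 (within the scatter), where swapping one group for another on the same carbonyl carbon moved the number only within the scatter. The two steps away from compound 1, a number 28 percentage points higher from compound 1 to compound 2 (beyond the scatter) and a number 20 percentage points higher from compound 1 to compound 3 (beyond the scatter), show that adding a carbonyl-bearing group to the aromatic nitrogen raised inhibition with either of the two groups tried on the carbonyl. Compound 4 keeps that carbonyl, so the expected step is one within the scatter, a number 4 percentage points higher from compound 3 to compound 4 (within the scatter). Compound 4 is therefore estimated at 94%, with an expected range of 84% to 100%.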

Compound 4, a percentage reported as inhibition, at one concentration (the size of the read-out at that concentration, not a potency): 31%
For compound 4 the middle estimate is 63 percentage points above the measured one, and the stated range ends above it.
By their numbers in this assay, from the lowest: compound 4; then compound 1; then compounds 3 and 2 (each within the scatter of the next).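

In this assay, the group on the carbonyl carbon turns out to matter a great deal: with morpholin-4-yl in place of isobutoxy there is a number 59 percentage points lower from compound 3 to compound 4 (beyond the scatter), and with morpholin-4-yl in place of dimethylamino there is a number 67 percentage points lower from compound 2 to compound 4 (beyond the scatter), although the two earlier groups had stayed within the scatter of each other. A carbonyl on the aromatic nitrogen therefore does not raise the number by itself, since adding (morpholin-4-yl)carbonyl gives a number 39 percentage points lower from compound 1 to compound 4 (beyond the scatter), the opposite direction to the rises seen for compound 2 and compound 3. Nothing available explains why this ring behaves so differently from dimethylamino, even though both join the carbonyl through a nitrogen.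

The compounds shown cannot say whether the drop goes with the ring as a whole or with the oxygen in it; piperidin-1-yl, the same ring with carbon in place of that oxygen, and open-chain diethylamino on the same carbonyl carbon would help separate these possibilities. They also leave open whether other rings on this carbonyl, such as pyrrolidin-1-yl, would share the low number of compound 4.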